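This account rests on a few compounds, and the source may have more. Where it says the series, first, only, none or still open, it means among the compounds named here.

Compound 1 `COc1cc(CCc2ccccc2)cc(OC)c1O`: 10900 nM
Compound 2 `COc1cc(CCc2cccc(F)c2)cc(OC)c1O`: 2240 nM

Both values come from a functional assay on A549 cells (Homo sapiens) for antiproliferative activity, read by MTT assay, with a stated time of 72 h; a lower number here means a stronger inhibitor, a higher number a weaker inhibitor. Of the two measured compounds, compound 1 has the higher number, which makes it the weaker inhibitor. Compound 3 `COc1cc(CCc2ccc([N+](=O)[O-])cc2)cc(OC)c1O` has not yet been measured. It keeps the core of compound 1 and differs in one place: nitro in place of hydrogen on an aromatic carbon. This is nitro in place of hydrogen on an aromatic carbon, para to a large group.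

For the measured compounds named here, the only measured step that bears on this is a 4.9-fold lower number from compound 1 to compound 2 (0.69 log units; beyond the scatter), a modest one with fluoro in place of hydrogen on an aromatic carbon. Fluoro is a different group from nitro, so this single step is only a loose guide. A modest step towards a lower number in this assay is expected, though it may be smaller. The estimated change is a 2.7-fold lower number from compound 1 to compound 3 (0.44 log units; beyond the scatter). Compound 3 is expected at 4000 nM, with an estimated range of 800 nM to 15000 nM.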

Compound 3, half-maximal inhibitory concentration: 9130 nM
The estimate for compound 3 lay 2.3-fold (0.36 log units) below the measured number; the measured number falls inside the stated range.
By their numbers in this assay, from the lowest: compound 2; then compounds 3 and 1 (each within the scatter of the next).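

Nitro on an aromatic carbon, para to a large group, gives a 1.2-fold lower number from compound 1 to compound 3 (0.08 log units; within the scatter), so compound 3 cannot be told apart from compound 1 in this assay. Fluoro in place of hydrogen gave a 4.9-fold lower number from compound 1 to compound 2 (0.69 log units; beyond the scatter), so compound 3 shows that putting a group on this aromatic ring does not by itself lower the number. No measurement shown here accounts for this difference in outcome.

On these data alone, compound 2 and compound 3 differ from each other in more than one place, so it stays open whether the outcome follows the group, its place on the ring, or both. An amine or a carboxylic acid para to a large group could show whether any group there moves the number beyond the scatter.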